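Flipping the double bond of compound 3

The source may report more compounds than this note shows. Statements on the series, on what has been measured and on what is new or still open speak of the compounds shown alone.

For the measured compounds named here, in a functional assay on P388 cells (Mus musculus) for inhibition (a lower number here means a stronger inhibitor, a higher number a weaker inhibitor), compound 3 (`CN(C)c1ccc(/C=C/c2ccc3ccccc3c2)cc1`) gives 3660 nM as the only true number so far. Compound 1 (`Cc1ccc(/C=C\c2ccc3ccccc3c2)cc1`) reads > 5000 nM and this is a limit. Compound 2 (`FC(F)(F)c1ccc(/C=C\c2ccc3ccccc3c2)cc1`) reads > 5000 nM and this too is a limit. That leaves a step that the two limits leave unreadable from compound 1 to compound 2 with no size to read. Compound 4 (`CN(C)c1ccc(/C=C\c2ccc3ccccc3c2)cc1`) differs from compound 3 as the two compounds have the same atoms and bonds and differ only in configuration as drawn: 1 of 1 stereo elements differ; a double bond is drawn E in compound 3 and Z in compound 4 with a double bond drawn E in compound 3 and Z in compound 4. Compound 1 and compound 2 are also drawn Z, yet the limit of > 5000 nM in this assay, at which 2 of the 3 values shown sit, gives no size for this change. No measured step sizes this flip, so the expected 1.2-fold lower number from compound 3 to compound 4 (0.09 log units; within the scatter) stays within the scatter, in no firm direction. Compound 4 is estimated at 3000 nM with an expected range from 600 nM to 10000 nM in this assay.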

Compound 4, half-maximal inhibitory concentration: 3660 nM
Estimate against measurement, compound 4: 1.2-fold (0.09 log units) below, within the range that was stated.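

In this assay, the flip of the double bond gives no change at the digits printed from compound 3 to compound 4 (within the scatter), so with dimethylamino on the aromatic carbon, the drawn configuration makes no readable difference: the fact that compounds 3 and 4 differ only in the configuration as drawn. Among the compounds drawn Z, dimethylamino in place of trifluoromethyl gives an at least 1.3-fold lower number from compound 2 to compound 4 (0.13 log units; that floor lies within the scatter), and dimethylamino in place of methyl gives an at least 1.3-fold lower number from compound 1 to compound 4 (0.13 log units; that floor lies within the scatter). Both steps start from a limit rather than a number, so neither is firm: the limit of > 5000 nM in this assay, at which 2 of the 4 values shown sit.

From the compounds shown here alone, whether a methoxy or hydroxyl group in place of dimethylamino would move the number stays open. So does whether the E and Z forms would also match with methyl or trifluoromethyl in that place.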